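Taking a methyl off the weakest inhibitor

This account rests on a few compounds, and the source may have more. Where it says the series, first, only, none or still open, it means among the compounds named here.

In a functional assay on L1210 cells (Mus musculus), with a stated time of 2 days (a higher number here means a weaker inhibitor, a lower number a stronger inhibitor), compound 1 `O=C1C=CCO[C@@H]1n1ccc(O)nc1=O` gives 92000 nM and compound 2 `Cc1cn([C@H]2OCC=CC2=O)c(=O)nc1O` gives 34000 nM. Compound 3 `C=C1C=CCO[C@@H]1n1cc(C)c(O)nc1=O` gives 486000 nM, the highest number of the three, which makes it the weakest inhibitor so far. It carries the same methyl as compound 2 but differs from it elsewhere in the structure.

The next compound to consider is compound 4 `C=C1C=CCO[C@@H]1n1ccc(O)nc1=O`, and the change is confined to one place: hydrogen in place of methyl on an aromatic carbon. In words, hydrogen takes the place of methyl on an aromatic carbon.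

Among the measured compounds shown here, only one measured step speaks to this swap: a 2.7-fold lower number from compound 1 to compound 2 (0.43 log units; beyond the scatter). That modest step puts methyl in place of hydrogen on an aromatic carbon, so it runs in the opposite direction to the change made here. Read in reverse, it suggests that losing the methyl should raise the number by a similarly modest amount. This is a single comparison, made on a different core, so the expectation remains loose.

The expected change is a 2.5-fold higher number from compound 3 to compound 4 (0.39 log units; beyond the scatter). For compound 4, the estimated value in this assay is 1200000 nM, with an expected range from 450000 nM to 3000000 nM.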

Compound 4, half-maximal inhibitory concentration: 549000 nM
For compound 4 the middle estimate is 2.2-fold (0.34 log units) above the measured one; measured number inside the range.
By their numbers in this assay, from the lowest: compound 2; then compound 1; then compounds 3 and 4 (each within the scatter of the next).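

On the core of compound 3, the swap at this aromatic carbon, ortho to a hydroxy group, makes no difference that this assay can resolve, with a 1.1-fold higher number from compound 3 to compound 4 (0.05 log units; within the scatter). The methyl therefore does not carry the same visible gain here that it showed on the core of compound 1, and compounds 3 and 4 cannot be told apart by their numbers. Even so, the two steps do not truly disagree, so this position cannot be said to respond differently on the two cores, and the gain seen on the core of compound 1 may be smaller or larger than that single step suggests: the same change on two cores in this assay, a 2.7-fold lower number (0.43 log units; beyond the scatter) from compound 1 to compound 2 and a 1.1-fold lower number (0.05 log units; within the scatter) from compound 4 to compound 3, 2.4-fold (0.38 log units) apart, within the scatter of two such steps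

The compounds shown place only hydrogen and methyl on this carbon, so it remains open whether a longer chain such as propyl, or an amine, would shift the number on either core. Among the compounds shown here, with only two matched pairs, it also remains open how much this position matters in general, and a third core carrying the same swap would be needed to show whether the methyl's contribution is real or lies within ordinary measurement variation.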